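A few compounds are considered here, and "the series" means these few. Any claim that something is new, unique, unknown or untested is made for them only; others in the source may bear on it.

Measured compounds in a functional assay on HM02 cells (Homo sapiens) for cytotoxicity; on this read-out higher numbers stand for weaker inhibition of growth and lower numbers for stronger inhibition of growth:
- compound 1 `C/C(=C/CC/C(C)=C/CC/C(C)=C/C(=O)C/C(C)=C/Cc1cc(O)cc(C)c1O)CO` gives 2.3 ug/mL
- compound 2 `C/C(=C/CC/C(C)=C/CC/C(C)=C\C(=O)C/C(C)=C/Cc1cc(O)cc(C)c1O)CO` gives 1.8 ug/mL

Among the measured compounds shown here, compound 1 stands with the higher of the two numbers in this assay, but its only neighbour is compound 2, and the step of a 1.3-fold lower number from compound 1 to compound 2 (0.11 log units; within the scatter) lies within the scatter, so the two are indistinguishable on these figures. That step is the only measured one in the series, and it rests on the fact that compounds 1 and 2 differ only in the configuration as drawn alone: a double bond drawn E in compound 1 and Z in compound 2, with all atoms and bonds the same.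

Compound 3 `C/C(=C\C(=O)C/C(C)=C/Cc1cc(O)cc(C)c1O)CC/C=C(\C)Cc1cc(C)co1` is not yet measured. Its difference from compound 1 is of another kind:

4-methylfuran-2-yl in place of 3-(hydroxymethyl)but-2-en-1-yl on a saturated chain carbon bound to a double-bonded chain carbon

For the measured compounds named here, no measured step bears on this replacement; the one step at hand, from compound 1 to compound 2, changes configuration only and leaves every group in place, and it moved the number by no more than the scatter. There is therefore nothing in the series from which a direction can be read for the exchange of the 3-(hydroxymethyl)but-2-en-1-yl end for 4-methylfuran-2-yl. The working expectation for compound 3 is a number close to that of compound 1, with a wide range on either side to allow for the unknown. The expected step of a 1.1-fold higher number from compound 1 to compound 3 (0.04 log units; within the scatter) is accordingly set near nothing. Compound 3 is estimated at 2.5 ug/mL, between 0.7 ug/mL and 9 ug/mL, in this assay.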

Compound 3, concentration for 50% growth inhibition: 0.3 ug/mL
Estimate against measurement, compound 3: 8.3-fold (0.92 log units) above, outside the stated range (below it).
By their numbers in this assay, from the lowest: compound 3; then compounds 2 and 1 (each within the scatter of the next).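

In this assay, among the compounds shown here, putting 4-methylfuran-2-yl in place of 3-(hydroxymethyl)but-2-en-1-yl on a saturated chain carbon bound to a double-bonded chain carbon gives a 7.7-fold lower number from compound 1 to compound 3 (0.88 log units; beyond the scatter), the first step beyond the scatter. For the compounds shown here, this end of the chain is thus a place where the number can move, which the only earlier step, a 1.3-fold lower number from compound 1 to compound 2 (0.11 log units; within the scatter), could not show; the hydroxymethyl group and the open chain are also not required for a number at the level of compound 3, 0.3 ug/mL. Nothing measured in the series accounts for this shift.

On these data alone, the exchange alters the ring, the hydrogen-bond donor and the double bond outside aromatic rings all at once, so it remains open which of these changes carries the shift, and whether the methyl on the furan contributes to it. Unsubstituted furan-2-yl, a thiophene or a carboxylic acid at this end of the chain would be the obvious next comparisons, and the compounds shown say nothing about any of them.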